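Chain Shortening in a Dithioacetal Diacid Series

This account rests on a few compounds, and the source may have more. Where it says the series, first, only, none or still open, it means among the compounds named here.

The series rests on two cores. Compound 1 `CCCCCCCCCCc1ccccc1C(SCCC(=O)O)SCCC(=O)O` carries a long saturated chain on the aromatic ring; compound 3 `CCCCCCCCCCCOc1ccccc1C(SCCC(=O)O)SCCC(=O)O` carries a chain joined through an oxygen on an aromatic ring. The difference between the two cores is not broken down here. In an assay on membranes from lung (Cavia porcellus) for binding affinity to cysteinyl leukotriene receptor (Homo sapiens) (on this read-out lower numbers stand for stronger inhibition and higher numbers for weaker inhibition), compound 1 gives 1180 nM, and compound 3 gives 287 nM, the lowest number of the three measured compounds.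

Compound 2 `CCCCCCCCc1ccccc1C(SCCC(=O)O)SCCC(=O)O` is compound 1 shortened: hydrogen in place of ethyl on a saturated chain carbon, eight bonds along the chain from an aromatic carbon. In this assay compound 2 gives 5670 nM, and the step is a 4.8-fold higher number from compound 1 to compound 2 (0.68 log units; beyond the scatter).

Compound 4 `CCCCCCCCCOc1ccccc1C(SCCC(=O)O)SCCC(=O)O` applies the same kind of change to the core of compound 3: hydrogen in place of ethyl on a saturated chain carbon, nine bonds along the chain from an oxygen on an aromatic ring. The place differs from the earlier case in its printed words, eight bonds along the chain from an aromatic carbon in compound 2 against nine bonds along the chain from an oxygen on an aromatic ring in compound 4, so the change is of the same kind rather than the same.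

In this assay the step from compound 3 to compound 4 is expected to be a 4.2-fold higher number from compound 3 to compound 4 (0.62 log units; beyond the scatter), because a 4.8-fold higher number from compound 1 to compound 2 (0.68 log units; beyond the scatter) is a change of the same kind as the shortening in hydrogen in place of ethyl on a saturated chain carbon, nine bonds along the chain from an oxygen on an aromatic ring and sets the size expected here. Compound 4 is therefore estimated at 1200 nM, with a likely span from 500 nM to 3500 nM.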

Compound 4, inhibition constant: 4090 nM
For compound 4 the middle estimate is 3.4-fold (0.53 log units) below the measured one, outside the stated range (above it).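

In this assay, shortening the chain on the core joined through an oxygen gives a 14-fold higher number from compound 3 to compound 4 (1.15 log units; beyond the scatter), a large step in the same direction as the shortening on the core of compound 1. The direction therefore carries from one core to the other in this pair, but the size does not, and a step taken from one core is a poor measure of the step on the other: the same change on two cores in this assay, a 4.8-fold higher number (0.68 log units; beyond the scatter) from compound 1 to compound 2 and a 14-fold higher number (1.15 log units; beyond the scatter) from compound 3 to compound 4, 3.0-fold (0.47 log units) apart, beyond the scatter of two such steps

This comparison rests on a single pair of steps and does not show why their sizes differ, nor whether the gap goes with the oxygen link, with the place of the change, or with the chain that remains, since eight bonds along the chain from an aromatic carbon and nine bonds along the chain from an oxygen on an aromatic ring are not the same place.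

Going by these compounds, each core shows only one shortening, so it remains open whether the numbers move steadily with chain length or change sharply at some length on either core. On these data alone, it is also open whether a longer chain, or a chain ending in an amine, would keep the gap between the two cores or close it.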